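The compounds below may be only part of what the source reports. "The series", "measured", "known", "first", "only" and "open" are said of these compounds alone.

Measured so far in an ADME assay on microsomes from liver (Homo sapiens) for metabolic stability; a higher number here means that the compound lasts longer, a lower number that the compound disappears faster:
compound 1, `CC(C)C(c1ncco1)c1ccc(-c2ccc3cccc(F)c3c2)[nH]c1=O`: 0.178 h
compound 2, `Cc1c[nH]c(C(c2ccc(-c3ccc4cccc(F)c4c3)[nH]c2=O)C(C)C)n1`: 0.09 h

Within the data shown here, compound 2 is one of only two compounds measured in this assay, and its number is not separated from that of compound 1: the step of a 2.0-fold lower number from compound 1 to compound 2 (0.30 log units; within the scatter) lies within the scatter, so the two half-lives count as the same. That single step, exchanging one five-membered heteroaryl ring for another on a saturated chain carbon bound to an aromatic carbon and a saturated chain carbon, is also the only one that bears on the next compound.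

Compound 3, `CC(C)C(Cc1nnc[nH]1)c1ccc(-c2ccc3cccc(F)c3c2)[nH]c1=O`, differs from compound 2 in the same place:

(4H-1,2,4-triazol-3-yl)methyl in place of 4-methyl-1H-imidazol-2-yl on a saturated chain carbon bound to an aromatic carbon and a saturated chain carbon

Among the measured compounds shown here, the one comparable step, the change from compound 1 to compound 2, did not move this assay beyond its scatter, and the change into compound 3 again keeps a small five-membered heteroaryl group at that position. Compound 3 is therefore expected to behave like compound 2, with a step of a 1.2-fold higher number from compound 2 to compound 3 (0.09 log units; within the scatter) that does not clear the scatter. The estimate for compound 3 in this assay is 0.11 h, with a range from 0.05 h to 0.25 h.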

Compound 3, half-life: 0.307 h
For compound 3 the middle estimate is 2.8-fold (0.45 log units) below the measured one, outside the stated range (above it).
By their numbers in this assay, from the lowest: compounds 2, 1 and 3 (each within the scatter of the next, the first and the last beyond it).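

In this assay, replacing 4-methyl-1H-imidazol-2-yl with (4H-1,2,4-triazol-3-yl)methyl on the saturated chain carbon bound to an aromatic carbon and a saturated chain carbon gives a 3.4-fold higher number from compound 2 to compound 3 (0.53 log units; beyond the scatter), so this is the only step shown at this position that clears the scatter. The other new step, a 1.7-fold higher number from compound 1 to compound 3 (0.24 log units; within the scatter), does not separate the 1,3-oxazol-2-yl group from the entering group, so only the two ends of the series, compound 2 and compound 3, can be told apart, and the group on this carbon matters for the half-life only in that one comparison. Nothing available explains this difference.

The entering group differs from 4-methyl-1H-imidazol-2-yl both in its ring and in how that ring is attached, so the compounds shown leave open which of the two accounts for the step. A 4H-1,2,4-triazol-3-yl ring set directly on the chain carbon, a (1,3-oxazol-2-yl)methyl group, or a different kind of group such as a carboxylic acid or an amine would be needed to show how far this position can carry the half-life.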